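Swapping an Aryl Group for Isopropyl on the Ring Nitrogen

A few compounds are considered here, and "the series" means these few. Any claim that something is new, unique, unknown or untested is made for them only; others in the source may bear on it.

Measured compounds:
compound 1, `COc1ncc(-c2ccc3c(c2)N(c2ccc(C)cc2)C(=O)CO3)cc1NS(=O)(=O)c1ccc(F)cc1`: 5870 nM
compound 2, `COc1cccc(N2C(=O)COc3ccc(-c4cnc5ccccc5c4)cc32)c1`: > 40000 nM

For the measured compounds named here, in a functional assay on A549 cells (Homo sapiens) for antiproliferative activity, read by MTT assay, with a stated time of 72 h (on this read-out higher numbers stand for weaker inhibition and lower numbers for stronger inhibition), compound 1 gives 5870 nM, the only number measured here. Compound 2 gives > 40000 nM, which is a limit of the assay and not a number; compound 2 sits at the limit of > 40000 nM in this assay, at which 1 of the 2 values shown sits. Compound 3, `COc1ncc(-c2ccc3c(c2)N(C(C)C)C(=O)CO3)cc1NS(=O)(=O)c1ccc(F)cc1`, has not been measured; it differs from compound 1 in one place: isopropyl in place of 4-methylphenyl on an amide-type nitrogen in a ring. Going by the values given here, no measured pair shows this change, so the size of the step is unknown. A loss beyond the scatter is expected. Compound 3 is expected to give 15000 nM, within 4000 nM to 40000 nM. The expected step of a 2.6-fold higher number from compound 1 to compound 3 (0.41 log units; beyond the scatter) is a weakening.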

Compound 3, half-maximal inhibitory concentration: 4920 nM
Compound 3: middle estimate off by 3.0-fold (0.48 log units), on the high side; low and high end bracket the measured number.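

In this assay, the ring nitrogen of the core takes isopropyl in place of 4-methylphenyl with a 1.2-fold lower number from compound 1 to compound 3 (0.08 log units; within the scatter). In this one pair, then, an aromatic ring on this nitrogen is not needed to keep the activity, and a smaller group with no ring serves equally well. Nothing shown here explains why the two groups read alike. As far as these compounds go, whether a longer chain, an amine or a carboxylic acid on this nitrogen would read the same stays open. So does whether this result holds when the rest of the molecule differs.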